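Methyl to Ethyl on the Ring Amide Nitrogen

The source may report more compounds than this note shows. Statements on the series, on what has been measured and on what is new or still open speak of the compounds shown alone.

Compound 1 `CC1CCN(c2ccc(Nc3ncc4c(n3)N(C3CCCC3)CC(=O)N4C)cc2)CC1`: in a functional assay on HT-29 cells (Homo sapiens) for inhibition, read by MTT assay, with a stated time of 48 h (on this read-out lower numbers stand for stronger inhibition and higher numbers for weaker inhibition), compound 1 gives > 30000 nM, which is a limit of the assay and not a number.
Compound 2 `CN1CCN(c2ccc(Nc3ncc4c(n3)N(C3CCCC3)CC(=O)N4C)nc2)CC1`: in this assay compound 2 gives 11100 nM.
Compound 3 `CCN1C(=O)CN(C2CCCC2)c2nc(Nc3ccc(N4CCC(C)CC4)cc3)ncc21`: in this assay compound 3 gives 24400 nM.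

Compound 3 is made from compound 1 by one change, (methyl in place of hydrogen on a saturated chain carbon bound to an amide-type nitrogen in a ring). That step reads an at least 1.2-fold lower number from compound 1 to compound 3 (0.08 log units; that floor lies within the scatter); since compound 1 only reached the limit (the limit of > 30000 nM in this assay, at which 1 of the 3 values shown sits), the step can only be given as a floor, and that floor lies within the scatter. Compound 2 holds the lowest of the two plain numbers, and compound 3 sits a step beyond the scatter from it. The difference between the core of compound 2 and the core of compound 1 is not broken down here.

Compound 4 `CCN1C(=O)CN(C2CCCC2)c2nc(Nc3ccc(N4CCN(C)CC4)cn3)ncc21` is the unmeasured compound. Among the compounds with values here, it differs from compound 2 by methyl in place of hydrogen on a saturated chain carbon bound to an amide-type nitrogen in a ring, which is the same change as the one from compound 1 to compound 3. The earlier step gave no clear shift, because compound 1 only reached its limit (the limit of > 30000 nM in this assay, at which 1 of the 3 values shown sits), so the size of that step is not known beyond a floor. The expectation for compound 4 therefore rests on compound 2 at 11100 nM and on a step of a 1.2-fold lower number from compound 2 to compound 4 (0.09 log units; within the scatter), estimated to stay close to the value of compound 2. Compound 4 is expected to give about 9000 nM in this assay, estimated to lie between 4000 nM and 22000 nM.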

Compound 4, half-maximal inhibitory concentration: 7840 nM
Compound 4: the middle estimate sits 1.1-fold (0.06 log units) above what was measured, within the range that was stated.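

In this assay, the swap of hydrogen for methyl on a saturated chain carbon bound to an amide-type nitrogen in a ring, which turns methyl to ethyl, gives a 1.4-fold lower number from compound 2 to compound 4 (0.15 log units; within the scatter), so on the core of compound 2 the change cannot be told apart from the ordinary spread of repeated measurements. Set beside the same change on the core of compound 1, the comparison goes only this far: the same change on two cores in this assay, an at least 1.2-fold lower number (0.08 log units; that floor lies within the scatter) from compound 1 to compound 3 and a 1.4-fold lower number (0.15 log units; within the scatter) from compound 2 to compound 4; the limit leaves it open whether they differ

What this does not show is that the change carries over from one core to the other with a steady size, since compound 1 stands at a limit of the assay and not at a number: the limit of > 30000 nM in this assay, at which 1 of the 4 values shown sits.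

The compounds shown leave open what a longer chain such as propyl, or a chain ending in an amine or a carboxylic acid, would give in this assay when placed on that ring nitrogen. They also leave open how much each part of the core of compound 1 and the core of compound 2 contributes, since those two compounds differ in more than one place.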